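The source may hold more compounds than are shown below. What is called first, only, known or untested is meant among the compounds shown, and "the series" means these compounds.

Three compounds share one core. Compound 1 `CCCCCCCCCCC[C@@H](C[C@@H]1OC(=O)[C@H]1CCCCCC)OC(=O)[C@@H](N)CC(C)C` carries a free amino group; in an assay on COS-7 cells for inhibition of diacylglycerol lipase-alpha (Homo sapiens), read by scintillation counting (on this read-out higher numbers stand for weaker inhibition and lower numbers for stronger inhibition), compound 1 gives only a limit, > 25000 nM. Compound 2 `CCCCCCCCCCC[C@@H](C[C@@H]1OC(=O)[C@H]1CCCCCC)OC(=O)CCNC=O` gives 600 nM in this assay. Compound 3 `CCCCCCCCCCC[C@@H](C[C@@H]1OC(=O)[C@H]1CCCCCC)OC(=O)[C@@H](NC(C)=O)C(C)C` gives 460 nM in this assay, the lowest of the two numbers measured, while compound 2 sits close by, within the scatter (a 1.3-fold lower number from compound 2 to compound 3 (0.12 log units; within the scatter)). The step of an at least 41-fold lower number from compound 1 to compound 2 (1.61 log units; beyond the scatter) and the step of an at least 54-fold lower number from compound 1 to compound 3 (1.73 log units; beyond the scatter) were both large, so the acylated amides stand far from the free amine.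

Compound 4 `CCCCCCCCCCC[C@@H](C[C@@H]1OC(=O)[C@H]1CCCCCC)OC(=O)[C@@H]1CCCN1C=O` is not yet measured. The change from compound 3 is 1-formylpyrrolidin-2-yl in place of 1-acetamido-2-methylpropyl on a carbonyl carbon. The amide is kept but the donor is lost. Among the measured compounds shown here, no measured step removes the donor while keeping the acyl group; the step that bears most closely is the one from compound 2 to compound 3, which was within the scatter. In this assay compound 4 is therefore expected to stay near compound 3, with a step of a 1.5-fold higher number from compound 3 to compound 4 (0.18 log units; within the scatter) that is not beyond the scatter. Compound 4 is estimated at 700 nM, between 200 nM and 2500 nM.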

Compound 4, half-maximal inhibitory concentration: 1100 nM
The estimate for compound 4 lay 1.6-fold (0.20 log units) below the measured number; measured number inside the range.
By their numbers in this assay, from the lowest: compounds 3, 2 and 4 (each within the scatter of the next, the first and the last beyond it). At a limit, above all of these: compound 1.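

In this assay, among the compounds shown here, putting 1-formylpyrrolidin-2-yl in place of 1-acetamido-2-methylpropyl on this carbonyl carbon gave a 2.4-fold higher number from compound 3 to compound 4 (0.38 log units; beyond the scatter) and thus the first change among the amides here to lie beyond the scatter, though it is only modest. Against 2-(formylamino)ethyl the same group gave a 1.8-fold higher number from compound 2 to compound 4 (0.26 log units; within the scatter) and stayed within the scatter, so compound 4 cannot be told apart from compound 2. The amides remain far from the free amine of compound 1, but an at least 22-fold lower number from compound 1 to compound 4 (1.35 log units; beyond the scatter) is only a bound, since compound 1 stands at a limit: the limit of > 25000 nM in this assay, at which 1 of the 4 values shown sits.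

The change from compound 3 to compound 4 removes the hydrogen-bond donor and adds the five-membered ring together, and the two are not separated here. Going by these compounds, how 1-acetylpyrrolidin-2-yl or an open-chain tertiary amide would read in this assay stays open.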